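Lengthening the acid chain on the shared core

The source may hold more compounds than are shown below. What is called first, only, known or untested is meant among the compounds shown, and "the series" means these compounds.

Three compounds share one core and differ only in the chain that hangs from the aromatic oxygen. Compound 1 `CCOC(=O)CCCCOc1ccc2c(=O)c(-c3ccc(O)cc3)coc2c1` carries an ethoxycarbonyl end and gives 240 nM in an assay (Cricetulus griseus) for inhibition of aldehyde dehydrogenase, mitochondrial (Homo sapiens); a higher number here means a weaker inhibitor, a lower number a stronger inhibitor. Compound 2 `NCCCCCCOc1ccc2c(=O)c(-c3ccc(O)cc3)coc2c1` ends in an amine and gives 100 nM in this assay, a change of a 2.4-fold lower number from compound 1 to compound 2 (0.38 log units; beyond the scatter). Compound 3 `O=C(O)CCCCCCOc1ccc2c(=O)c(-c3ccc(O)cc3)coc2c1` ends in a free acid and gives 50 nM in this assay; against compound 1 the step is a 4.8-fold lower number from compound 1 to compound 3 (0.68 log units; beyond the scatter), while against compound 2 it is a 2.0-fold lower number from compound 2 to compound 3 (0.30 log units; within the scatter), so compound 3 sits at the low end of the three numbers but is not separated from compound 2 beyond the scatter.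

Compound 4 `O=C(O)CCCCCCCOc1ccc2c(=O)c(-c3ccc(O)cc3)coc2c1` keeps the acid and the core; the difference is carboxymethyl in place of carboxy on a saturated chain carbon, six bonds along the chain from an oxygen on an aromatic ring. For the measured compounds named here, none of the measured steps is of this kind: both steps from compound 1 swap the end group, and the step from compound 2 to compound 3 exchanges amino for carboxy at the same place. Going by the values given here, no measured step therefore bears directly on adding one chain carbon, and the expectation is a step of no change at the digits printed from compound 3 to compound 4 (within the scatter), within the scatter. Compound 4 is estimated at 50 nM in this assay, with a range from 20 nM to 130 nM.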

Compound 4, half-maximal inhibitory concentration: 40 nM
For compound 4 the middle estimate is 1.3-fold (0.10 log units) above the measured one; low and high end bracket the measured number.
By their numbers in this assay, from the lowest: compounds 4, 3 and 2 (each within the scatter of the next, the first and the last beyond it); then compound 1.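

In this assay, carboxymethyl in place of carboxy on a saturated chain carbon, six bonds along the chain from an oxygen on an aromatic ring, gives a 1.3-fold lower number from compound 3 to compound 4 (0.10 log units; within the scatter), so this one-carbon extension of the acid chain produces no change that can be told from the scatter. The longer acid does stand clear of the amine end, at a 2.5-fold lower number from compound 2 to compound 4 (0.40 log units; beyond the scatter), whereas the shorter acid does not, at a 2.0-fold lower number from compound 2 to compound 3 (0.30 log units; within the scatter), although that contrast rests on two closely similar steps and marks no large gap. Against the ethoxycarbonyl end the longer acid gives a 6.0-fold lower number from compound 1 to compound 4 (0.78 log units; beyond the scatter), which extends to a further chain length what the shorter acid showed with a 4.8-fold lower number from compound 1 to compound 3 (0.68 log units; beyond the scatter).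

The compounds shown leave open whether a still longer carboxylic acid chain or a shorter one would hold these numbers, and whether an ethoxycarbonyl end or an amine on the chain of compound 4 would separate the end group from chain length. No experimental evidence is available here to explain these numbers.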